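From 3-Fluorophenyl to 2-Methoxyphenyl in Compound 1

A few compounds are considered here, and "the series" means these few. Any claim that something is new, unique, unknown or untested is made for them only; others in the source may bear on it.

In a toxicity assay on MT4 cells (Homo sapiens) for cytotoxicity, read by MTT assay (a lower number here means that less compound is tolerated, a higher number that more compound is tolerated), compound 1 `Cc1cc(-c2cccc(F)c2)cc(C)c1Oc1cc(N)nc(Nc2ccc(C#N)cc2)n1` gives 24700 nM and compound 2 `Cc1cc(-c2ccc(F)cc2)cc(C)c1Oc1cc(N)nc(Nc2ccc(C#N)cc2)n1` gives 23100 nM. The two stand level at the upper end of the three measured numbers, since the step between them is a 1.1-fold lower number from compound 1 to compound 2 (0.03 log units; within the scatter). Compound 3 `Cc1ccc(-c2cc(C)c(Oc3cc(N)nc(Nc4ccc(C#N)cc4)n3)c(C)c2)cc1` gives 10000 nM, which lies lower than both, with steps of a 2.5-fold lower number from compound 1 to compound 3 (0.39 log units; beyond the scatter) and a 2.3-fold lower number from compound 2 to compound 3 (0.36 log units; beyond the scatter).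

Compound 4 `COc1ccccc1-c1cc(C)c(Oc2cc(N)nc(Nc3ccc(C#N)cc3)n2)c(C)c1` carries 2-methoxyphenyl in place of 3-fluorophenyl on an aromatic carbon. Among the measured compounds shown here, all three measured steps change this same group, so they are the only guide, yet none of them involves a methoxy group. Moving the fluoro group made no difference beyond the scatter, as a 1.1-fold lower number from compound 1 to compound 2 (0.03 log units; within the scatter) shows. The one ring without fluorine, in compound 3, brought a modest drop, seen in a 2.5-fold lower number from compound 1 to compound 3 (0.39 log units; beyond the scatter). On that single precedent, a small downward move is expected, no larger than that drop and possibly not beyond the scatter. The expected change is a 1.8-fold lower number from compound 1 to compound 4 (0.25 log units; within the scatter). For compound 4 the estimated value is 14000 nM, with an expected range of 6000 nM to 30000 nM.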

Compound 4, half-maximal cytotoxic concentration: 21800 nM
Compound 4: the middle estimate sits 1.6-fold (0.19 log units) below what was measured; the range from low to high includes it.
By their numbers in this assay, from the lowest: compound 3; then compounds 4, 2 and 1 (each within the scatter of the next).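

In this assay the 2-methoxyphenyl ring of compound 4 stands level with both fluorinated rings (a 1.1-fold lower number from compound 1 to compound 4 (0.05 log units; within the scatter) and a 1.1-fold lower number from compound 2 to compound 4 (0.03 log units; within the scatter)), so at this position, para to a large group on the shared core, a fluoro group on the ring is not needed to keep the number at that level. Compound 4 carries no fluorine either, yet the comparison with the other fluorine-free ring goes the other way (a 2.2-fold higher number from compound 3 to compound 4 (0.34 log units; beyond the scatter)), so the modest drop at compound 3 cannot be read as the loss of fluorine alone, and compound 3 is now the only one of the four that stands apart from the rest. No measured evidence bears on why these rings differ or match.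

From the compounds shown here alone, what remains open is whether the level shared by compounds 1, 2 and 4 would hold with an amine or a carboxylic acid on this ring. Going by these compounds, it is also open whether the lower number of compound 3 belongs to its methyl group as such, which a 4-methoxyphenyl or 4-ethylphenyl ring would help to settle.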